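The compounds below may be only part of what the source reports. "The series", "measured", "known", "first", "only" and "open" are said of these compounds alone.

Compound 3, `O=C(Nc1ccc(Cl)cc1)Nc1ccc(Oc2ccc(-c3ncc[nH]3)cc2)cc1`, stands lowest of the three measured compounds: in a functional assay on A549 cells (Homo sapiens) for inhibition, read by MTT assay and WST assay, with a stated time of 72 h, tested at 10 uM (a higher number here means more inhibition of growth at the concentration tested, a lower number less inhibition of growth), compound 3 gives 8.86%, while compound 1, `O=C(Nc1ccc(Oc2ccc(-c3nccs3)cc2)cc1)Nc1ccc(F)c(C(F)(F)F)c1`, gives 76.4% and compound 2, `O=C(Nc1ccc(Oc2ccc(-c3nccs3)cc2)cc1)Nc1cc(C(F)(F)F)ccc1Cl`, gives 75.5%. Compound 4, `O=C(Nc1ccc(Oc2ccc(-c3ncc[nH]3)cc2)cc1)Nc1cc(Br)cc(C(F)(F)F)c1`, differs from compound 3 by 3-bromo-5-(trifluoromethyl)phenyl in place of 4-chlorophenyl on an amide-type nitrogen. Among the compounds with values here, the only measured single-change step, a number 0.9 percentage points lower from compound 1 to compound 2 (within the scatter), exchanges one trifluoromethyl-bearing aryl for another and does not touch a chlorophenyl, so no measured step bears directly on this change; compounds 1 and 2 also differ from compound 3 elsewhere in the core. The expectation therefore rests on the two trifluoromethyl-bearing compounds being high. The step is estimated as a number 36.1 percentage points higher from compound 3 to compound 4 (beyond the scatter), and this estimate carries wide uncertainty. Compound 4 is estimated at 45%, between 12% and 78%.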

Compound 4, percent growth inhibition at one concentration: 44.1%
For compound 4 the middle estimate is 0.9 percentage points above the measured one; the range from low to high includes it.
By their numbers in this assay, from the lowest: compound 3; then compound 4; then compounds 2 and 1 (each within the scatter of the next).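

Read in this assay, the aryl group on the amide-type nitrogen matters on this core: 3-bromo-5-(trifluoromethyl)phenyl in place of 4-chlorophenyl gives a number 35.2 percentage points higher from compound 3 to compound 4 (beyond the scatter) on an otherwise unchanged structure. The entering group brings both bromine and trifluoromethyl, so this single step cannot assign the rise to either one. No available evidence explains the rise.

As far as these compounds go, it remains open how this core would respond to 3-(trifluoromethyl)phenyl without the bromine or to 3-bromophenyl without the trifluoromethyl. From the compounds shown here alone, the effect of an amine or a carboxylic acid on this aryl ring also remains open.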